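The source may hold more compounds than are shown below. What is called first, only, known or untested is meant among the compounds shown, and "the series" means these compounds.

Of the compounds shown here, three on a shared core have been measured in a functional assay on THP-1 cells (Homo sapiens) for antiproliferative activity, tested at 100 uM; on this read-out higher numbers stand for a stronger effect at the one concentration tested and lower numbers for a weaker effect. Compound 1 `COC(=O)c1ccc(CS(=O)(=O)Nc2ccc3c(c2)cc(C)c(=O)n3C)cc1` gives 93%, compound 2 `Cc1cc2cc(NS(=O)(=O)Cc3ccc(C(=O)NO)cc3)ccc2n(C)c1=O` gives 89%, and compound 3 `COc1ccc(C(=O)NO)cc1S(=O)(=O)Nc1ccc2c(c1)cc(C)c(=O)n2C` gives 43%. From compound 2 to compound 1 the change is methoxy in place of hydroxyamino on a carbonyl carbon, and the read-out moves by a number 4 percentage points higher from compound 2 to compound 1 (within the scatter). Compound 3 stands lowest of the three, and its values against compound 2 and against compound 1 show gaps beyond the scatter. The difference between the core of compound 3 and the core of compound 2 is not broken down here. Compound 4 `COC(=O)c1ccc(OC)c(S(=O)(=O)Nc2ccc3c(c2)cc(C)c(=O)n3C)c1` remains to be measured; it differs from compound 3 by methoxy in place of hydroxyamino on a carbonyl carbon, the same change at the same place. For compound 4 the expected step is a number 2 percentage points higher from compound 3 to compound 4 (within the scatter), because the earlier step of a number 4 percentage points higher from compound 2 to compound 1 (within the scatter) was within the scatter. Compound 4 is thus estimated at 45%, between 25% and 65%.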

Compound 4, a percentage reported as inhibition, at one concentration (the size of the read-out at that concentration, not a potency): 102%
Beside the measured number, compound 4's estimate is 57 percentage points below it; measured number above the stated range.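

In this assay, methoxy in place of hydroxyamino on a carbonyl carbon gives a number 59 percentage points higher from compound 3 to compound 4 (beyond the scatter), and the same change does not have the same size on the two cores: the same change on two cores in this assay, a number 4 percentage points higher (within the scatter) from compound 2 to compound 1 and a number 59 percentage points higher (beyond the scatter) from compound 3 to compound 4, 55 percentage points apart, beyond the scatter of two such steps. The effect of this change in the series therefore depends on the core carrying it, so the step from one pair cannot simply be transferred to another. These two pairs do not show which difference between the cores accounts for this, and they set no rule for any further core.

Still open, from the compounds shown here alone, is how a carboxylic acid or a primary amide in place of the hydroxycarbamoyl would read on either core. A read-out at one concentration also leaves open whether these compounds would show a stronger or weaker effect at any other concentration.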